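Swapping a Cyanoethyl Chain for Phenyl on the Amine

This account rests on a few compounds, and the source may have more. Where it says the series, first, only, none or still open, it means among the compounds named here.

Compound 2 `C#CCSc1nc(NCCC#N)c2ccncc2n1` shares its core with compound 1 `C#CCSc1nc(NCCC(C)C)c2ccncc2n1`; the two differ only in the group on the saturated chain carbon two bonds along from the ring nitrogen. In a functional assay on MGC-803 cells (Homo sapiens) for inhibition, read by MTT assay, with a stated time of 72 h (on this read-out lower numbers stand for stronger inhibition and higher numbers for weaker inhibition), compound 1 gives > 80000 nM, which is a limit of the assay rather than a number. In this assay compound 2 gives > 80000 nM, again a limit and not a number. The step that the two limits leave unreadable from compound 1 to compound 2 cannot be read because of the limit of > 80000 nM in this assay, at which 2 of the 2 values shown sit. Where compound 2 stands is therefore known only as a limit.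

Compound 3 `C#CCSc1nc(Nc2ccccc2)c2ccncc2n1` alters the amine substituent: phenyl in place of 2-cyanoethyl on a nitrogen on an aromatic ring. No measured step bears directly on this change; the only step shown, a step that the two limits leave unreadable from compound 1 to compound 2, is unreadable, and neither measured compound carries an aromatic group on that nitrogen. Both measured compounds sit at the limit (the limit of > 80000 nM in this assay, at which 2 of the 2 values shown sit). The step from compound 2 to compound 3 is expected to be an at least 1.3-fold lower number from compound 2 to compound 3 (0.12 log units; that floor lies within the scatter), with a result at the limit remaining the most likely outcome. Compound 3 is estimated at 60000 nM, within an expected range from 15000 nM to 200000 nM.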

Compound 3, half-maximal inhibitory concentration: 16200 nM
Estimate against measurement, compound 3: 3.7-fold (0.57 log units) above; the measured number falls inside the stated range.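

In this assay, phenyl on a nitrogen on an aromatic ring gives the only actual number among the compounds shown, with compound 3 at 16200 nM. Phenyl in place of 2-cyanoethyl gives an at least 4.9-fold lower number from compound 2 to compound 3 (0.69 log units; beyond the scatter), and phenyl in place of isopentyl gives an at least 4.9-fold lower number from compound 1 to compound 3 (0.69 log units; beyond the scatter), so this position can respond to the choice of group, which the step from compound 1 to compound 2 could not show because it cannot be read. Of the three compounds, only the one carrying an aromatic ring at this nitrogen has a value off the limit, while the two with open chains stay on it: the limit of > 80000 nM in this assay, at which 2 of the 3 values shown sit.

From the compounds shown here alone, it remains open whether the aromatic ring itself matters, since a cyclohexyl group, with a ring that is not aromatic, or a benzyl group, with one carbon placed before the phenyl ring, would separate the ring from its attachment to the nitrogen. It is also unknown whether a chloro or methoxy group on the phenyl ring would move the number for a relative of compound 3 further from 16200 nM.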